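Compound 3 to compound 4: ethynyl for thiophen-2-yl

The source may hold more compounds than are shown below. What is called first, only, known or untested is meant among the compounds shown, and "the series" means these compounds.

Going by the values given here, in a functional assay on CCRF-CEM cells (Homo sapiens), read by MTT assay, with a stated time of 72 h (a higher number here means a weaker inhibitor, a lower number a stronger inhibitor), compound 1 (`CSc1ncnc2c1c(-c1ccoc1)cn2[C@@H]1O[C@H](CO)[C@@H](O)[C@H]1O`) is the only compound returning a number, with 14200 nM as its value. Compound 2 (`Nc1nc(N)c2c(-c3cccs3)cn([C@@H]3O[C@H](CO)[C@@H](O)[C@H]3O)c2n1`) gives only the limit > 20000 nM and no number. Compound 3 (`Cc1nc(N)c2c(-c3cccs3)cn([C@@H]3O[C@H](CO)[C@@H](O)[C@H]3O)c2n1`) likewise gives only the limit > 20000 nM and no number. Compound 3 therefore stands at the limit of > 20000 nM in this assay, at which 2 of the 3 values shown sit, and cannot be placed more finely.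

Compound 4 (`C#Cc1cn([C@@H]2O[C@H](CO)[C@@H](O)[C@H]2O)c2nc(C)nc(N)c12`) carries ethynyl in place of thiophen-2-yl on an aromatic carbon, and the rest of the structure is unchanged. Among the compounds with values here, the one measured step is a step that the two limits leave unreadable from compound 2 to compound 3 and it concerns methyl in place of amino, not this exchange, so it supplies no size to carry over. Within the data shown here, the only guide to a readable value is compound 1 at 14200 nM on a differently substituted core. With compound 3 at a limit, any readable change in this assay would be toward stronger inhibition, though another limit remains quite possible. The expected move is an at least 2.8-fold lower number from compound 3 to compound 4 (0.45 log units; beyond the scatter) with wide uncertainty. The estimate for compound 4 is 7000 nM as the expected value, with 700 nM to 20000 nM as its estimated range.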

Compound 4, half-maximal inhibitory concentration: > 20000 nM
Compound 4: a limit, no number; the forecaster's own chance of this, stated with the estimate: 45%; middle value at least 2.8-fold (0.45 log units) away from the limit.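

Compound 3 and compound 4 both stand at a limit rather than a number, so the exchange of thiophen-2-yl for ethynyl gives no readable step: the limit of > 20000 nM in this assay, at which 3 of the 4 values shown sit.

The compounds shown leave open whether ethynyl and thiophen-2-yl differ at all on the shared core in this assay, and what numbers compound 3 and compound 4 would return.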